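Replacing a ring ethyl amine with a fluorocyclobutyl amide

A few compounds are considered here, and "the series" means these few. Any claim that something is new, unique, unknown or untested is made for them only; others in the source may bear on it.

Of the compounds shown here, two of a shared core have been measured in an assay on HEK293 cells for positive allosteric modulation of metabotropic glutamate receptor 5 (Homo sapiens), read by FLIPR, with a stated time of 1 h; on this read-out higher numbers stand for an effect only at larger amounts of compound and lower numbers for an effect already at smaller amounts. Compound 1, `O=C1NCCc2nc(C#Cc3ccccc3F)sc21`, carries a carbonyl within its core and a fluorine on the phenyl ring; in this assay compound 1 gives 1500 nM. Compound 2, `CCN1CCc2nc(C#Cc3ccccc3)sc2C1`, bears an ethyl on the ring nitrogen instead. For compound 2 the result in this assay is only a limit, > 10000 nM, and not a number. Compound 2 therefore stands at the limit of > 10000 nM in this assay, at which 1 of the 2 values shown sits, the weaker end of what has been seen so far. Within the data shown here, no step between the two measured compounds is counted, since they differ in more than one place.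

Compound 3, `O=C(C1CC(F)C1)N1CCc2nc(C#Cc3ccccc3)sc2C1`, has not yet been measured in this assay. It differs from compound 2 in one place: (3-fluorocyclobutyl)carbonyl in place of ethyl on an amine nitrogen in a ring. The change swaps a small alkyl for a carbonyl-bearing group on the same nitrogen, and only compound 1, which also holds a carbonyl, has shown a measurable number. The account expects a gain for compound 3 well beyond the scatter, a step of an at least 20-fold lower number from compound 2 to compound 3 (1.30 log units; beyond the scatter). For compound 3 an effect near 500 nM is estimated, within a range from 80 nM to 5000 nM.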

Compound 3, half-maximal effective concentration: 85 nM
Compound 3: middle estimate off by 5.9-fold (0.77 log units), on the high side; low and high end bracket the measured number.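

Among these compounds, on the amine nitrogen in a ring, putting (3-fluorocyclobutyl)carbonyl in place of ethyl gives, in this assay, an at least 110-fold lower number from compound 2 to compound 3 (2.07 log units; beyond the scatter), the first step that can be read between compounds differing in one place. It shows that the group on this nitrogen can by itself move the shared core from no measured number to a clear effect at small amounts, and that this nitrogen accepts a much larger group than ethyl, one carrying a carbonyl and a four-membered ring, with a gain and not a loss. The step has a floor and no fixed size, for compound 2 gives only a limit and not a number, so the true gain may be larger still: the limit of > 10000 nM in this assay, at which 1 of the 3 values shown sits.

The entering group brings in the carbonyl, the fluorine and the four-membered ring of carbon together, so this one step cannot say which of them carries the gain; a plain acetyl or a cyclobutylcarbonyl without fluorine on the same nitrogen would be needed to separate them. Also open, on these data alone, is how a fluorine on the phenyl ring, as compound 1 holds, would act together with this amide.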